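Trading the Benzyl Arm for tert-Butyl

The compounds below may be only part of what the source reports. "The series", "measured", "known", "first", "only" and "open" are said of these compounds alone.

Measured compounds:
Compound 1, `CCCCc1cnc(Cc2ccc(-c3ccccc3C(=O)O)cc2)[nH]1`: > 10000 nM
Compound 2, `Cc1cccc(Cc2cnc(CCc3ccc(-c4ccccc4C(=O)O)cc3)[nH]2)c1`: 75 nM

Among the compounds with values here, in an in vitro functional assay on cells for agonist activity at Bombesin receptor subtype-3 (Mus musculus), read by luminescence and calcium flux (on this read-out lower numbers stand for an effect already at smaller amounts and higher numbers for an effect only at larger amounts of compound), compound 2 gives 75 nM, the only actual number recorded. For compound 1 the result of > 10000 nM is a limit of the assay rather than a number, which is all that is recorded for it (the limit of > 10000 nM in this assay, at which 1 of the 2 values shown sits). Within the data shown here, compound 2 thus stands as the single compound with a measured potency, with no second number beside it to rank against.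

Compound 3, `CC(C)(C)c1cnc(CCc2ccc(-c3ccccc3C(=O)O)cc2)[nH]1`, has not yet been measured. It differs from compound 2 in one place: tert-butyl in place of 3-methylbenzyl on an aromatic carbon. Among the measured compounds shown here, no step between two measured compounds is recorded, so the effect of this change cannot be read from an earlier pair. The compound 1 limit shows that a small saturated group on that ring carbon can go together with no measurable activity, though compound 1 also differs elsewhere. On that basis the step from compound 2 to compound 3 is expected to be a clear loss in this assay, beyond the usual scatter, of about a 27-fold higher number from compound 2 to compound 3 (1.43 log units; beyond the scatter). Compound 3 is estimated at 2000 nM, with a range from 300 nM to 10000 nM.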

Compound 3, half-maximal effective concentration: 2750 nM
Compound 3: middle estimate off by 1.4-fold (0.14 log units), on the low side, and the stated range covers the measured number.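

In this assay, within the data shown here, this is the first single change that can be read at this aromatic carbon of the five-membered aromatic ring with 2 nitrogen, and it is a large one: tert-butyl in place of 3-methylbenzyl gives a 37-fold higher number from compound 2 to compound 3 (1.56 log units; beyond the scatter). The position is therefore not indifferent to the group it carries, yet the 3-methylbenzyl group with its six-membered aromatic ring is not required for a measurable effect, since compound 3 still gives 2750 nM. Among these compounds, compound 1 differs from both in more than one place and supplies no step here, and its entry remains a limit and not a number: the limit of > 10000 nM in this assay, at which 1 of the 3 values shown sits.

This one pair cannot tell whether the loss follows the aromatic ring itself, the methyl on it or simply the larger group, and a plain benzyl, a cyclohexylmethyl or a phenyl group at this carbon would begin to separate these readings. It also leaves open whether a ring bearing an amine or a methoxy group in place of the methyl could match or pass compound 2.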